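The compounds below may be only part of what the source reports. "The series", "measured", "known", "first", "only" and "open" are said of these compounds alone.

Working notes on the series. Among the measured compounds shown here, compound 2 `COc1ccc2cc(C(C)c3nnc4n3N=C(c3ccc(Cl)cc3Cl)CS4)ccc2c1` gives 14600 nM in a functional assay on MCF7 cells (Homo sapiens) for inhibition, read by sulforhodamine B assay, with a stated time of 72 h (on this read-out lower numbers stand for stronger inhibition and higher numbers for weaker inhibition), and stands highest of the three numbers so far; compound 1 `COc1ccc2cc(C(C)c3nnc4n3N=C(c3ccc(C(F)(F)F)cc3)CS4)ccc2c1` gives 6900 nM and compound 3 `CC(C)Cc1ccc(C(C)c2nnc3n2N=C(c2ccc(OC(F)(F)F)cc2)CS3)cc1` gives 1100 nM. Compound 4 `COc1ccc2cc(C(C)c3nnc4n3N=C(c3ccc([N+](=O)[O-])cc3)CS4)ccc2c1` is not yet measured. It differs from compound 2 by 4-nitrophenyl in place of 2,4-dichlorophenyl on a carbon with a double bond to nitrogen. For the measured compounds named here, the one measured step at the same place is a 2.1-fold higher number from compound 1 to compound 2 (0.33 log units; beyond the scatter), which bears directly here, since compound 4 again carries a group on that carbon with only one substituent on the phenyl ring. Going by the values given here, a return toward the number of compound 1 is therefore expected, with a step of about a 1.8-fold lower number from compound 2 to compound 4 (0.26 log units; within the scatter), since 4-nitrophenyl has no measured precedent in this assay. The estimate for compound 4 is 8000 nM, with a range from 3000 nM to 25000 nM.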

Compound 4, half-maximal inhibitory concentration: 18800 nM
Compound 4: the middle estimate sits 2.4-fold (0.37 log units) below what was measured, within the range that was stated.
By their numbers in this assay, from the lowest: compound 3; then compound 1; then compounds 2 and 4 (each within the scatter of the next).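

In this assay, 4-nitrophenyl and 2,4-dichlorophenyl on the carbon with a double bond to nitrogen are not separated, with a 1.3-fold higher number from compound 2 to compound 4 (0.11 log units; within the scatter) lying within the scatter. Nitro in place of trifluoromethyl on the aromatic carbon gives a 2.7-fold higher number from compound 1 to compound 4 (0.44 log units; beyond the scatter) as a modest step beyond the scatter, so among these three groups on the shared core only the 4-(trifluoromethyl)phenyl of compound 1 stands apart.

Open, on these data alone, is how 4-aminophenyl or 4-carboxyphenyl at this place would read on the same core. No evidence is available on what lies behind these steps.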